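Chain-end phenyl on the diaminopyrimidine series: step to compound 3

The source may report more compounds than this note shows. Statements on the series, on what has been measured and on what is new or still open speak of the compounds shown alone.

Measured so far:
compound 1, `CCCCNc1nc(N)nc(C)c1CCCC`, 780 nM
compound 2, `CCCCCc1c(C)nc(N)nc1NCCCC`, 1220 nM

Compound 2 gives 1220 nM in an assay on HEK293 cells for agonist activity at Toll-like receptor 8 (Homo sapiens), read by spectrophotometry; on this read-out higher numbers stand for an effect only at larger amounts of compound and lower numbers for an effect already at smaller amounts. Within the data shown here, compound 1 gives 780 nM, and the one measured step, a 1.6-fold higher number from compound 1 to compound 2 (0.19 log units; within the scatter), leaves the two within the scatter of each other, so nothing in the data so far separates them.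

Compound 3 is `CCCCNc1nc(N)nc(C)c1CCCCCc1ccccc1`. It differs from compound 2 by phenyl in place of hydrogen on a saturated chain carbon, five bonds along the chain from an aromatic carbon. Among the measured compounds shown here, the only measured step, a 1.6-fold higher number from compound 1 to compound 2 (0.19 log units; within the scatter), concerns a methyl added at the end of the chain, and it changes the number no more than repeated measurement would. For the measured compounds named here, a phenyl at the chain end is a much larger addition than that methyl, and no measured pair tests such an addition, so the direction of the step is not determined by the data. Given that the chain extension from compound 1 to compound 2 was flat, the estimate for compound 3 is a step of a 1.2-fold lower number from compound 2 to compound 3 (0.09 log units; within the scatter), that is, no change beyond the scatter. The expected value for compound 3 is therefore 1000 nM, with a wide range from 200 nM to 5000 nM.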

Compound 3, half-maximal effective concentration: 830 nM
The estimate for compound 3 lay 1.2-fold (0.08 log units) above the measured number, and the stated range covers the measured number.
By their numbers in this assay, from the lowest: compounds 1, 3 and 2 (each within the scatter of the next).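

In this assay, phenyl in place of hydrogen on a saturated chain carbon, five bonds along the chain from an aromatic carbon, gives a 1.5-fold lower number from compound 2 to compound 3 (0.17 log units; within the scatter), and the same compound, read as benzyl in place of hydrogen on the shorter chain, gives a 1.1-fold higher number from compound 1 to compound 3 (0.03 log units; within the scatter). The methyl step alone covered only a small addition, whereas these steps show that a group of 6 heavy atoms with one six-membered aromatic ring at the chain end also stays within the scatter, so all three compounds remain within the scatter of each other and the series gives no sign so far that this position responds to what is added there. Nothing available on these compounds accounts for this flat reading.

The compounds shown leave open whether an amine or a carboxylic acid at the chain end, in place of the phenyl, would move the number beyond the scatter. They also leave open whether a longer chain carrying the phenyl, or a pyridine ring in its place, would stay as flat as the three compounds here.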